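Trimming the 3,5-dimethylphenyl of compound 2 to phenyl

A few compounds are considered here, and "the series" means these few. Any claim that something is new, unique, unknown or untested is made for them only; others in the source may bear on it.

compound 1 `CCCCc1ccc2c(c1)C(=O)C(=O)N2` — > 10000 nM, a limit of the assay, not a number
compound 2 `COC(=O)/C=C/c1ccc2c(c1)C(=O)C(=O)N2Cc1cc(C)cc(C)c1` — 40 nM

For the measured compounds named here, in a functional assay on K562 cells (Homo sapiens) for cytotoxicity, read by MTT assay, with a stated time of 48 h (a higher number here means a weaker inhibitor, a lower number a stronger inhibitor), compound 2 gives 40 nM, the only actual number in the set so far. For compound 1 the result in this assay is > 10000 nM, which is a limit of the assay and not a number (the limit of > 10000 nM in this assay, at which 1 of the 2 values shown sits). Compound 3 `COC(=O)/C=C/c1ccc2c(c1)C(=O)C(=O)N2Cc1ccccc1` differs from compound 2 by phenyl in place of 3,5-dimethylphenyl on a saturated chain carbon bound to an amide-type nitrogen in a ring. Going by the values given here, no measured step of this kind exists, so the expectation rests on the structural change alone: a small step, likely toward weaker inhibition and possibly within the scatter, a 2.0-fold higher number from compound 2 to compound 3 (0.30 log units; within the scatter). Compound 3 is expected to give 80 nM, estimated between 30 nM and 250 nM.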

Compound 3, half-maximal inhibitory concentration: 40 nM
Compound 3: the middle estimate sits 2.0-fold (0.30 log units) above what was measured; measured number inside the range.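

In this assay, phenyl in place of 3,5-dimethylphenyl gives no change at the digits printed from compound 2 to compound 3 (within the scatter). On this saturated chain carbon bound to an amide-type nitrogen in a ring, the 3,5-dimethylphenyl is therefore not required for the value of compound 2, and the plain phenyl serves as well. Nothing measured here gives a cause for this flat step.

Still open, as far as these compounds go, is whether an amine or a carboxylic acid on the phenyl would keep this value. A longer chain in place of the saturated chain carbon is equally untested in the compounds shown.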